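From 4-methoxyphenyl to 3-chlorophenyl: a step without a readable guide

The compounds below may be only part of what the source reports. "The series", "measured", "known", "first", "only" and "open" are said of these compounds alone.

- Compound 1 (`C/C(=C\CC/C(C)=C/CC[C@@H]1[C@@]2(C)CCC(=O)C(C)(C)[C@H]2CC[C@@]1(C)O)CC/C=C(\C)C(=O)OCc1cn(-c2ccccc2[N+](=O)[O-])nn1`): > 150000 nM
- Compound 2 (`COc1ccc(-n2cc(COC(=O)/C(C)=C/CC/C(C)=C/CC/C(C)=C/CC[C@@H]3[C@@]4(C)CCC(=O)C(C)(C)[C@H]4CC[C@@]3(C)O)nn2)cc1`): > 150000 nM

In an ADME assay on L132 cells (Homo sapiens) for cytotoxicity, read by MTT assay, with a stated time of 48 h (on this read-out lower numbers stand for stronger inhibition and higher numbers for weaker inhibition), compound 2 gives > 150000 nM as its reading, which is a limit and not a number. Compound 1 gives > 150000 nM as its reading, and that too is a limit.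

Compound 3 (`C/C(=C\CC/C(C)=C/CC[C@@H]1[C@@]2(C)CCC(=O)C(C)(C)[C@H]2CC[C@@]1(C)O)CC/C=C(\C)C(=O)OCc1cn(-c2cccc(Cl)c2)nn1`) differs from compound 2 in one group: 3-chlorophenyl in place of 4-methoxyphenyl on an aromatic nitrogen with 3-chlorophenyl in place of 4-methoxyphenyl on an aromatic nitrogen of a five-membered aromatic ring with 3 nitrogen.

Going by the values given here, the only measured step that bears on this change is a step that the two limits leave unreadable from compound 1 to compound 2 and it swaps a group on the same aromatic nitrogen, but it has no readable size. Both measured compounds rest on the limit of > 150000 nM in this assay, at which 2 of the 2 values shown sit, and so no number is available to compare. Among the compounds with values here, with that step as the only guide, no step beyond the scatter is expected in this assay and no direction can be given.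

The estimated step is a number no higher from compound 2 to compound 3 (the limit leaves the size open) and no larger move is expected. For compound 3 the estimate is 150000 nM with an expected range of 60000 nM to 300000 nM and a reading that is again only a limit is the likeliest outcome.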

Compound 3, half-maximal inhibitory concentration: 94200 nM
For compound 3 the middle estimate is 1.6-fold (0.20 log units) above the measured one; the range from low to high includes it.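

In this assay compound 3 gives 94200 nM as a true number, so a group on this aromatic nitrogen of the five-membered ring can bring the reading into the range where it can be counted. The 3-chlorophenyl group gives an at least 1.5-fold lower number from compound 2 to compound 3 (0.20 log units; that floor lies within the scatter) and an at least 1.5-fold lower number from compound 1 to compound 3 (0.20 log units; that floor lies within the scatter) as the smallest steps that the readings allow, and neither floor shows by itself a change larger than repeated measurements would give. From the compounds shown here alone, the real size of either step stays unknown because only a floor can be drawn from these readings, and the evidence for that is this: the limit of > 150000 nM in this assay, at which 2 of the 3 values shown sit.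

The compounds shown leave open whether the chlorine atom itself or its place on the phenyl ring matters for this reading. A plain phenyl, a 4-chlorophenyl or a 3-aminophenyl group on the same aromatic nitrogen would help separate those two possibilities, and a reading that is a number for a second compound would give the step a measured size.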